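The source may report more compounds than this note shows. Statements on the series, on what has been measured and on what is new or still open speak of the compounds shown alone.

Measured so far in an ADME assay on J774.A1 cells (Mus musculus) for cytotoxicity, read by MTT assay, with a stated time of 48 h; on this read-out higher numbers stand for lower toxicity in this test and lower numbers for higher toxicity in this test:
- compound 1 `COC(=O)c1c([N+](=O)[O-])noc1-c1ccc([N+](=O)[O-])cc1`: "not determined" (no result reported)
- compound 2 `O=C(NCc1cccc(Br)c1)c1c([N+](=O)[O-])noc1-c1ccc([N+](=O)[O-])cc1`: "not determined" (no result reported)
- compound 3 `CC(C)CCNC(=O)c1c([N+](=O)[O-])noc1-c1ccc([N+](=O)[O-])cc1`: 67000 nM

Compound 1 has no single number to stand on in this assay, and compound 2 is in the same position. Within the data shown here, only compound 3 gives a number, 67000 nM, so the series has one anchor and no measured step.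

The next compound is compound 4 `COC(=O)c1c(NCc2ccc(Cl)cc2)noc1-c1ccc([N+](=O)[O-])cc1`. The structural change is (4-chlorobenzyl)amino in place of nitro on an aromatic carbon. In words, this is (4-chlorobenzyl)amino in place of nitro on an aromatic carbon. Among the measured compounds shown here, no measured compound carries the (4-chlorobenzyl)amino group, so the data do not show what this exchange does in this assay.

For the measured compounds named here, with no number for compound 1, no step from it can be sized. The expectation therefore rests on compound 3 at 67000 nM: a value in the same region, with at most a modest move towards lower numbers that may not exceed the usual scatter. For compound 4 the estimated value is 40000 nM, with an expected range of 12000 nM to 130000 nM.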

Compound 4, half-maximal cytotoxic concentration: 78300 nM
The estimate for compound 4 lay 2.0-fold (0.29 log units) below the measured number; low and high end bracket the measured number.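

Among these compounds, no step from compound 1 to compound 4 can be read in this assay, as compound 1 has no single number there. The compounds shown leave open what (4-chlorobenzyl)amino in place of nitro does on this read-out. No supporting evidence bears on this result.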